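This account rests on a few compounds, and the source may have more. Where it says the series, first, only, none or still open, it means among the compounds named here.

Compound 3 `CC(C)c1cnc(NC(=O)CCCOc2ccccc2)s1` carries an isopropyl group on its shared core. For the measured compounds named here, in an ADME assay on microsomes from liver (Mus musculus) for metabolic stability, read by LC-MS, using NADPH, tested at 1 uM (a higher number here means that the compound lasts longer, a lower number that the compound disappears faster), compound 3 gives 0.0333 h, the lowest of the three values known so far. Going by the values given here, compound 1 `N#Cc1cnc(NC(=O)CCCOc2cccc(Cl)c2)s1` gives 0.133 h, and compound 2 `N#Cc1cnc(NC(=O)CCCOc2cccc(C(F)(F)F)c2)s1` gives 0.517 h; the only measured step, a 3.9-fold higher number from compound 1 to compound 2 (0.59 log units; beyond the scatter), concerns the aryl ring, not the core, so no measured step bears directly on the change at hand. Compound 4 `Cc1cnc(NC(=O)CCCOc2ccccc2)s1` differs from compound 3 by methyl in place of isopropyl on an aromatic carbon. Among the compounds with values here, with no direct precedent, a small rise is expected, and the step of a 2.4-fold higher number from compound 3 to compound 4 (0.38 log units; beyond the scatter) is the estimate made here. Compound 4 is therefore expected to give about 0.08 h, within a range from 0.03 h to 0.25 h.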

Compound 4, half-life: 0.0333 h
Compound 4: middle estimate off by 2.4-fold (0.38 log units), on the high side; the measured number falls inside the stated range.
By their numbers in this assay, from the lowest: compounds 3 and 4 (each within the scatter of the next); then compound 1; then compound 2.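

In this assay, methyl in place of isopropyl on this aromatic carbon, next to the ring sulfur, gives no change at the digits printed from compound 3 to compound 4 (within the scatter). For the compounds shown here, this is the first measured step at this position, and it shows that going from the larger alkyl group to the smaller one leaves the number unmoved here, whereas the earlier step concerned only the aryl ring. Nothing available here accounts for this result. Going by these compounds, it remains open whether a nitrile at this position, on the unsubstituted aryl ring of compound 3, would shift the number. The same question stands for an amine or a carboxylic acid there.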